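Terminal aryl change in the growth-inhibition series

The source may hold more compounds than are shown below. What is called first, only, known or untested is meant among the compounds shown, and "the series" means these compounds.

In a functional assay on KB cells (Homo sapiens) for inhibition, read by sulforhodamine B assay (a lower number here means a stronger inhibitor of growth, a higher number a weaker inhibitor of growth), compound 1 (`FC(F)(F)c1ccc(-c2ccc(-c3ccc(-c4nc5ccccc5[nH]4)cc3)cc2)cc1`) gives 47200 nM, compound 2 (`COc1ccc(-c2ccc(-c3ccc(-c4nc5ccccc5[nH]4)cc3)cc2)cc1`) gives 47200 nM, and compound 3 (`CN(C)c1ccc(-c2ccc(-c3ccc(-c4nc5ccccc5[nH]4)cc3)cc2)cc1`) gives 39300 nM. Compound 3 therefore stands within the scatter of both others. Compound 4 (`Clc1cccc(-c2ccc(-c3ccc(-c4nc5ccccc5[nH]4)cc3)cc2)c1`) has 3-chlorophenyl in place of 4-(dimethylamino)phenyl on an aromatic carbon. Within the data shown here, three measured steps bear on this change: no change at the digits printed from compound 1 to compound 2 (within the scatter), a 1.2-fold lower number from compound 1 to compound 3 (0.08 log units; within the scatter) and a 1.2-fold lower number from compound 2 to compound 3 (0.08 log units; within the scatter). All three exchange a group at this end of the molecule and stay within the scatter. Among the measured compounds shown here, no measured compound carries 3-chlorophenyl, so the range is kept wide. The expected step is a 1.1-fold higher number from compound 3 to compound 4 (0.06 log units; within the scatter), with nothing expected beyond the scatter. Compound 4 is estimated at 45000 nM, with an expected range of 25000 nM to 80000 nM.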

Compound 4, concentration for 50% growth inhibition: 32300 nM
Estimate against measurement, compound 4: 1.4-fold (0.14 log units) above; low and high end bracket the measured number.
By their numbers in this assay, from the lowest: compounds 4, 3, 1 and 2 (each within the scatter of the next).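

Replacing the terminal group with 3-chlorophenyl in this assay gives a 1.2-fold lower number from compound 3 to compound 4 (0.09 log units; within the scatter), a 1.5-fold lower number from compound 2 to compound 4 (0.16 log units; within the scatter) and a 1.5-fold lower number from compound 1 to compound 4 (0.16 log units; within the scatter). The earlier compounds shown here varied only among 4-(trifluoromethyl)phenyl, 4-methoxyphenyl and 4-(dimethylamino)phenyl, whereas 3-chlorophenyl shows that a chlorine-bearing ring placed differently at this end also leaves all four compounds within the scatter. Nothing on hand explains this flat response.

On these data alone, it remains open whether a carboxylic acid or a primary amine on the terminal ring would move the number beyond the scatter. Any effect of changes to the shared core also remains open.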